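The source may report more compounds than this note shows. Statements on the series, on what has been measured and on what is new or still open speak of the compounds shown alone.

Compound 1 `COc1cc(-c2cc(C(=O)/C=C/c3ccc(Cl)cc3)nc3cc(-c4ccccc4)nn23)cc(OC)c1OC` is the starting point here. In a functional assay on DU-145 cells (Homo sapiens) for antiproliferative activity, read by MTT assay, with a stated time of 24 h (on this read-out lower numbers stand for stronger inhibition and higher numbers for weaker inhibition), compound 1 gives 19500 nM. Going by the values given here, its one measured relative, compound 2 `COc1ccc(-c2cc(C(=O)/C=C/c3ccc(Cl)cc3)nc3cc(-c4ccccc4)nn23)cc1OC`, gives 22400 nM in this assay; the only measured step, a 1.1-fold higher number from compound 1 to compound 2 (0.06 log units; within the scatter), hydrogen in place of methoxy on an aromatic carbon, leaves the two numbers within the scatter of each other. Compound 3 `COc1cc(-c2cc(/C=C/C(=O)c3ccccc3)nc3cc(-c4ccccc4)nn23)cc(OC)c1OC` differs from compound 1 by 2-benzoylethenyl in place of (2-(4-chlorophenyl)ethenyl)carbonyl on an aromatic carbon. Among the compounds with values here, no measured step touches this part of the molecule, so nothing in the data points to a move beyond the scatter in either direction. Compound 3 is therefore expected to give about 25000 nM in this assay, between 8000 nM and 80000 nM, an expected step of a 1.3-fold higher number from compound 1 to compound 3 (0.11 log units; within the scatter).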

Compound 3, half-maximal inhibitory concentration: 34300 nM
Compound 3: middle estimate off by 1.4-fold (0.14 log units), on the low side, within the range that was stated.
By their numbers in this assay, from the lowest: compounds 1, 2 and 3 (each within the scatter of the next).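

Unlike the methoxy step, this one alters the side chain on the shared core: 2-benzoylethenyl replaces (2-(4-chlorophenyl)ethenyl)carbonyl, which removes the chlorine and places the carbonyl at the other end of the ethenyl link. Even so, a 1.8-fold higher number from compound 1 to compound 3 (0.25 log units; within the scatter) in this assay, so neither feature visibly separates the compounds at this position. No available evidence explains this result.

Because both features differ together, their separate contributions remain unresolved. Also open, going by these compounds, is how an amine or a carboxylic acid at this position would read.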